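Removing a methyl from an oxygen in a cell-kill series

The source may hold more compounds than are shown below. What is called first, only, known or untested is meant among the compounds shown, and "the series" means these compounds.

Among the measured compounds shown here, compound 1 `COc1cc(-c2nn(-c3cccc(NC(=O)Nc4cc(C(F)(F)F)cc(C(F)(F)F)c4)c3)cc2-c2ccncc2)ccc1Cl` is the only one of three measured compounds to give a number in a functional assay on A498 cells (Homo sapiens) for inhibition, read by sulforhodamine B assay, with a stated time of 48 h (a lower number here means that less compound is tolerated, a higher number that more compound is tolerated), where compound 1 gives 7140 nM. Compound 2 `COc1cc(-c2nn(-c3cccc(NC(=O)Nc4ccc(Cl)c(Cl)c4)c3)cc2-c2ccncc2)ccc1Cl` shares the same ring-bound oxygen bearing a methyl, but the difference between the two cores is not broken down here. In this assay compound 2 gives > 50000 nM, which is a limit of the assay and not a number. Compound 3 `O=C(Nc1cccc(-n2cc(-c3ccncc3)c(-c3ccc(Cl)c(O)c3)n2)c1)Nc1ccc(Cl)c(Cl)c1` carries the change hydrogen in place of methyl on an oxygen on an aromatic ring relative to compound 2. In this assay compound 3 gives > 32500 nM, again a limit rather than a number. The resulting step that the two limits leave unreadable from compound 2 to compound 3 cannot be sized because the limit of > 50000 nM in this assay, at which 1 of the 3 values shown sits, and the limit of > 32500 nM in this assay, at which 1 of the 3 values shown sits, bracket it on both sides.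

Compound 4 `O=C(Nc1cccc(-n2cc(-c3ccncc3)c(-c3ccc(Cl)c(O)c3)n2)c1)Nc1cc(C(F)(F)F)cc(C(F)(F)F)c1` carries the same change hydrogen in place of methyl on an oxygen on an aromatic ring relative to compound 1. With the measured step unreadable, the expectation rests on compound 1 alone, whose 7140 nM is the single anchor, so the step from compound 1 to compound 4 is expected to be small but uncertain, a 1.3-fold higher number from compound 1 to compound 4 (0.10 log units; within the scatter). Compound 4 is therefore estimated at 9000 nM, within 3000 nM to 40000 nM.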

Compound 4, concentration lethal to 50% of the cells: 16000 nM
Compound 4: the middle estimate sits 1.8-fold (0.25 log units) below what was measured; measured number inside the range.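

In this assay, changing methoxy to hydroxy on the core of compound 1 gives a 2.2-fold higher number from compound 1 to compound 4 (0.35 log units; beyond the scatter), so on this one core the phenol form needs more compound to reach the same cell kill. No measurement shown here explains why the number moves, and this single pair sets no rule for the series. The same change on the core of compound 2 cannot be read, as both compound 2 and compound 3 sit at limits of the assay and not at numbers, so these data neither confirm nor contradict that the step carries over from one core to the other.

The compounds shown leave open how the number would respond to a longer chain on the same oxygen, such as ethyl, or to an amine in place of the hydroxy group. They also leave open whether the step would keep its direction and size on a third core with a different group on the urea.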